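The source may report more compounds than this note shows. Statements on the series, on what has been measured and on what is new or still open speak of the compounds shown alone.

Measured in a functional assay on DU-145 cells (Homo sapiens) for inhibition, read by trypan blue exclusion, with a stated time of 96 h; a lower number here means a stronger inhibitor of growth, a higher number a weaker inhibitor of growth:
- compound 1 `Cc1ccc(S/C(=C/c2ccc(Cl)c(Cl)c2)C(=O)c2ccc(Br)cc2)cc1`: 50000 nM
- compound 2 `COc1ccc(/C=C(/Sc2ccc(C)cc2)C(=O)c2ccc(Br)cc2)cc1`: 50000 nM
- compound 3 `Cc1ccc(S/C(=C/c2ccc(C)s2)C(=O)c2ccc(Br)cc2)cc1`: > 100000 nM

Compound 3 gives only a limit, > 100000 nM, and not a number. Compound 4 `Cc1ccc(S/C(=C/c2c(O)cc(O)cc2O)C(=O)c2ccc(Br)cc2)cc1` differs from it at one place: 2,4,6-trihydroxyphenyl in place of 5-methylthiophen-2-yl on a double-bonded chain carbon bound to a double-bonded chain carbon. Three measured steps at this same place bear on the change: no change at the digits printed from compound 1 to compound 2 (within the scatter), an at least 2.0-fold higher number from compound 1 to compound 3 (0.30 log units; that floor lies within the scatter) and an at least 2.0-fold higher number from compound 2 to compound 3 (0.30 log units; that floor lies within the scatter). None of them shows a change beyond the scatter, though the last two are only floors. Compound 4 has a six-membered aromatic ring at this place, and so does compound 2 at 50000 nM, so a similar level is expected. The expected result is an at least 2.0-fold lower number from compound 3 to compound 4 (0.30 log units; that floor lies within the scatter), a small step towards a lower number. For compound 4 the estimated value is 50000 nM, with an expected range from 12000 nM to 100000 nM.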

Compound 4, concentration for 50% growth inhibition: > 100000 nM
Compound 4: no number, only a limit (the forecaster's own chance of this, stated with the estimate: 30%); middle value at least 2.0-fold (0.30 log units) away from the limit.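

In this assay, compound 4 shows that a six-membered aromatic ring at this place does not by itself give a readable number: the change brings an at least 2.0-fold higher number from compound 2 to compound 4 (0.30 log units; that floor lies within the scatter) and an at least 2.0-fold higher number from compound 1 to compound 4 (0.30 log units; that floor lies within the scatter). Both steps are only floors, so they show no change beyond the scatter. The step between compound 3 and compound 4 cannot be read, since each gives only a limit: the limit of > 100000 nM in this assay, at which 2 of the 4 values shown sit.

The compounds shown leave open how far compound 3 and compound 4 lie past that limit. They also leave open whether an aminophenyl group at this place would give a readable number.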